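Swapping the benzyl substituent on a sulfonamide chain

The source may report more compounds than this note shows. Statements on the series, on what has been measured and on what is new or still open speak of the compounds shown alone.

Measured so far:
- compound 1 `O=S(=O)(NCCCNCc1ccc(Cl)cc1)c1cc(C(F)(F)F)cc(C(F)(F)F)c1`: 2300 nM
- compound 2 `COc1ccc(CNCCCNS(=O)(=O)c2cc(C(F)(F)F)cc(C(F)(F)F)c2)cc1OC`: 5300 nM
- compound 3 `COc1cccc(CNCCCNS(=O)(=O)c2cc(C(F)(F)F)cc(C(F)(F)F)c2)c1`: 6600 nM

In a toxicity assay on MCF-10A cells (Homo sapiens) for inhibition, read by MTT assay, with a stated time of 72 h (a higher number here means a weaker inhibitor of growth, a lower number a stronger inhibitor of growth), compound 3 gives the highest number of the three, so it is the weakest growth inhibitor measured here. Compound 4 `O=S(=O)(NCCCNCc1ccc(C(F)(F)F)cc1)c1cc(C(F)(F)F)cc(C(F)(F)F)c1` differs from it in one place: 4-(trifluoromethyl)phenyl in place of 3-methoxyphenyl on a saturated chain carbon bound to an amine nitrogen. The step that bears on this is a 2.9-fold higher number from compound 1 to compound 3 (0.46 log units; beyond the scatter), a modest rise when a halogen-bearing ring gave way to a methoxy-bearing one. Compound 4 returns to a halogen-bearing ring, so a modest fall in the number, back toward compound 1, is expected: a 2.6-fold lower number from compound 3 to compound 4 (0.42 log units; beyond the scatter). Compound 4 is therefore estimated at 2500 nM, with a range from 1000 nM to 6500 nM.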

Compound 4, concentration for 50% growth inhibition: 3300 nM
Compound 4: middle estimate off by 1.3-fold (0.12 log units), on the low side; the range from low to high includes it.
By their numbers in this assay, from the lowest: compounds 1, 4, 2 and 3 (each within the scatter of the next, the first and the last beyond it).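

In this assay the step of a 1.4-fold higher number from compound 1 to compound 4 (0.16 log units; within the scatter) lies within the scatter, so trifluoromethyl and chloro cannot be told apart at this position. The steps of a 2.0-fold lower number from compound 3 to compound 4 (0.30 log units; within the scatter) and a 1.6-fold lower number from compound 2 to compound 4 (0.21 log units; within the scatter) also lie within the scatter, so compound 4 does not separate clearly from the methoxy-bearing compounds, and the gap seen between compound 1 and compound 3 does not extend to a second electron-neutral-free comparison of ring groups. Nothing measured here explains these results. On these data alone, whether a nitrile or a carboxylic acid on the ring, or a longer chain, would move the number beyond the scatter remains open.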